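Replacing a Nitro Group with Hydroxy on the Aryl Ketone

The source may report more compounds than this note shows. Statements on the series, on what has been measured and on what is new or still open speak of the compounds shown alone.

The measured compounds:
- compound 1, `COc1cc(C(=O)/C=C\Nc2ccc(-c3nc4cc(OC)c(OC)c(OC)c4s3)cc2)c(Br)c(OC)c1OC`, gives 15600 nM in a functional assay on MDA-MB-231 cells (Homo sapiens) for antiproliferative activity, read by sulforhodamine B assay, with a stated time of 48 h; a higher number here means a weaker inhibitor, a lower number a stronger inhibitor
- compound 2, `COc1ccc(C(=O)/C=C\Nc2ccc(-c3nc4cc(OC)c(OC)c(OC)c4s3)cc2)cc1[N+](=O)[O-]`, gives 17100 nM in this assay
- compound 3, `COc1ccc2nc(-c3ccc(N/C=C\C(=O)c4ccc(OC)c(F)c4)cc3)sc2c1`, gives 1100 nM in this assay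

Compound 2 carries the highest number of the three in this assay, though its gap to compound 1 lies within the scatter, so the two cannot be ranked. Compound 3, whose core also differs in other places, gives a number that is well beyond the scatter lower than that of compound 2.

Compound 4, `COc1ccc(C(=O)/C=C\Nc2ccc(-c3nc4cc(OC)c(OC)c(OC)c4s3)cc2)cc1O`, has not yet been measured in this assay. It differs from compound 2 in a single place:

hydroxy in place of nitro on an aromatic carbon

Among the compounds with values here, no measured pair shows this exact change, so its size in this assay is unknown. Since compound 3 with a small group on the same ring reaches 1100 nM, a drop from compound 2 is expected, but with wide uncertainty. The estimated step of a 4.3-fold lower number from compound 2 to compound 4 (0.63 log units; beyond the scatter) is taken to be beyond the scatter. Compound 4 is expected to give about 4000 nM, within 600 nM to 25000 nM.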

Compound 4, half-maximal inhibitory concentration: 18100 nM
Compound 4: middle estimate off by 4.5-fold (0.66 log units), on the low side; the range from low to high includes it.
By their numbers in this assay, from the lowest: compound 3; then compounds 1, 2 and 4 (each within the scatter of the next).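

In this assay the swap of nitro for hydroxy, on a ring where the new group sits ortho to a methoxy group, gives a 1.1-fold higher number from compound 2 to compound 4 (0.02 log units; within the scatter) and this lies within the scatter, so the two compounds cannot be ranked. On this core, then, the read-out does not separate the two groups, even though hydroxy brings a hydrogen-bond donor that nitro lacks and has fewer heavy atoms. No measurement is available to explain this result.

Still open, going by these compounds, is whether an amine or a carboxylic acid at this same place on the core of compound 2 would shift the number beyond the scatter. Compound 3 differs from these compounds in more than one place, so it cannot show which of its differences goes with its lower number.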